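A few compounds are considered here, and "the series" means these few. Any claim that something is new, unique, unknown or untested is made for them only; others in the source may bear on it.

Compound 1 `c1ccc(C2=NCCN2)cc1` gives the lowest number of the two measured in an assay on brain for binding affinity to Amine oxidase [flavin-containing] A (Rattus norvegicus), read by spectrophotometry (on this read-out lower numbers stand for stronger inhibition and higher numbers for weaker inhibition), at 28800 nM. Compound 2 `COc1cc(C2=NCCN2)cc(OC)c1OC` lies beyond the scatter from it; in this assay compound 2 gives 114000 nM. Compound 3 `O=[N+]([O-])c1ccc(C2=NCCN2)cc1` differs from compound 1 by nitro in place of hydrogen on an aromatic carbon. Among the compounds with values here, no step between measured compounds isolates this change, and the gap from compound 1 to compound 2 concerns a different substitution, so it offers no guide. For compound 3 the expected step is a 1.0-fold higher number from compound 1 to compound 3 (0.02 log units; within the scatter), none beyond the scatter in either direction. Compound 3 is estimated at 30000 nM, within 8000 nM to 120000 nM.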

Compound 3, inhibition constant: 181000 nM
The estimate for compound 3 lay 6.0-fold (0.78 log units) below the measured number; the measured number lies above the stated range.
By their numbers in this assay, from the lowest: compound 1; then compounds 2 and 3 (each within the scatter of the next).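

At this position, on an aromatic carbon para to a group of 5 heavy atoms, nitro in place of hydrogen is not a neutral change in this assay, giving a 6.3-fold higher number from compound 1 to compound 3 (0.80 log units; beyond the scatter). Within the data shown here, this is the only step that isolates a single change, and it runs toward weaker inhibition, so hydrogen is favoured over nitro here. No available evidence bears on this step.

On these data alone, whether any group at this position improves on hydrogen remains open. An amine, fluorine or a carboxylic acid in place of nitro would test how general this step is.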